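The compounds below may be only part of what the source reports. "The series", "measured", "known", "first", "only" and "open" are said of these compounds alone.

Measured compounds:

Compound 1, `O=C(/C=C/c1ccc(F)cc1)NS(=O)(=O)c1ccc(Cl)cc1`: 2.6 ug/mL
Compound 2, `O=C(/C=C/c1ccc(F)cc1)NS(=O)(=O)c1ccc(Br)cc1`: 2.8 ug/mL
Compound 3, `O=C(/C=C/c1ccc(Cl)cc1)NS(=O)(=O)c1ccc(Cl)cc1`: 2.5 ug/mL

All three were run in a functional assay on B16-F10 cells (Mus musculus) for antiproliferative activity, read by ELISA and MTT assay, with a stated time of 48 h; a higher number here means a weaker inhibitor, a lower number a stronger inhibitor. The three numbers sit close together. The step of a 1.1-fold higher number from compound 1 to compound 2 (0.03 log units; within the scatter) is the one made by bromo in place of chloro on an aromatic carbon. The step of a 1.0-fold lower number from compound 1 to compound 3 (0.02 log units; within the scatter) is made by chloro in place of fluoro on an aromatic carbon. Neither step leaves the scatter, so no order among compound 1, compound 2 and compound 3 can be read from these numbers; compound 3 merely has the lowest of the three numbers, and its two neighbours lie within the scatter of it.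

Compound 4, `O=C(/C=C/c1ccc(Cl)cc1)NS(=O)(=O)c1ccc(Br)cc1`, is not yet measured in this assay. It differs from compound 3 by bromo in place of chloro on an aromatic carbon. Going by the values given here, this is the same change as the one from compound 1 to compound 2, at the same kind of place; the pair compound 1 and compound 2 is the only measured example of it. The cores of compound 3 and compound 1 differ by chloro in place of fluoro on an aromatic carbon, and that change itself did nothing beyond the scatter.

The step expected from compound 3 to compound 4 is a 1.1-fold higher number from compound 3 to compound 4 (0.03 log units; within the scatter), a size chosen beside the measured step because a 1.1-fold higher number from compound 1 to compound 2 (0.03 log units; within the scatter) stayed within the scatter. On that basis compound 4 is estimated at 2.7 ug/mL in this assay, with the expected range running from 1.5 ug/mL to 4.8 ug/mL.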

Compound 4, half-maximal inhibitory concentration: 2.8 ug/mL
Beside the measured number, compound 4's estimate is 1.0-fold (0.02 log units) below it, within the range that was stated.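

In this assay bromo in place of chloro gives a 1.1-fold higher number from compound 3 to compound 4 (0.05 log units; within the scatter) and matches the earlier step on the other core: the same change on two cores in this assay, a 1.1-fold higher number (0.03 log units; within the scatter) from compound 1 to compound 2 and a 1.1-fold higher number (0.05 log units; within the scatter) from compound 3 to compound 4, 1.0-fold (0.02 log units) apart, within the scatter of two such steps.
Chloro in place of fluoro, now read with bromo on the other ring, gives no change at the digits printed from compound 2 to compound 4 (within the scatter) and also matches its earlier step: the same change on two cores in this assay, a 1.0-fold lower number (0.02 log units; within the scatter) from compound 1 to compound 3 and no change at the digits printed (within the scatter) from compound 2 to compound 4, 1.0-fold (0.02 log units) apart, within the scatter of two such steps.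
Going by these compounds alone, each exchange therefore carries from one core to the other without any step leaving the scatter, but with one pair of cores per change, this shows only that these halogen exchanges make no readable difference here; it gives no order among fluoro, chloro and bromo and no reason to expect the same on other cores.

The compounds shown carry only these three halogens as ring substituents, so the effect of an amine, a carboxylic acid, a methoxy group or a longer chain at those places remains open. Also open, as far as these compounds go, is what a methyl group in place of the amide hydrogen, or a saturated chain in place of the double bond, would do in this assay.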